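A few compounds are considered here, and "the series" means these few. Any claim that something is new, unique, unknown or untested is made for them only; others in the source may bear on it.

Measured compounds:
compound 1 `O=S(=O)(NCCCNCc1ccc(C(F)(F)F)cc1)c1cc(C(F)(F)F)cc(C(F)(F)F)c1`, with 2500 nM
compound 2 `O=S(=O)(NCCCCCCNCc1ccc(Br)cc1)c1ccc2c(c1)OCC2`, with 13000 nM

Both compounds were tested in a functional assay on MIA PaCa-2 cells (Homo sapiens) for inhibition, read by MTT assay, with a stated time of 72 h; a lower number here means a stronger inhibitor of growth, a higher number a weaker inhibitor of growth. Compound 1 gives the lowest of the two numbers; compound 2 gives a higher number, and the gap between them lies beyond the usual scatter of repeated measurements. The two compounds differ in several places at once, so no single change can be tied to that gap.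

Compound 3 `O=S(=O)(NCCCNCc1ccc(Cl)cc1)c1cc(C(F)(F)F)cc(C(F)(F)F)c1` is the next compound, and it has not yet been measured. It keeps the core of compound 1 and differs from it in one place only: chloro in place of trifluoromethyl on an aromatic carbon.

Going by the values given here, no measured pair shows the effect of this exact change. Compound 1 and compound 2 carry different halogen-bearing or trifluoromethyl-bearing benzyl groups, but they also differ in the chain and in the sulfonyl-bearing ring, so they give no clean guide. The step from compound 1 to compound 3 is expected to be small, near the scatter, and if anything toward a weaker inhibitor, that is, a 1.4-fold higher number from compound 1 to compound 3 (0.15 log units; within the scatter). Compound 3 is therefore estimated at 3500 nM, within a range from 1200 nM to 10000 nM.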

Compound 3, concentration for 50% growth inhibition: 2800 nM
Estimate against measurement, compound 3: 1.3-fold (0.10 log units) above; low and high end bracket the measured number.
By their numbers in this assay, from the lowest: compounds 1 and 3 (each within the scatter of the next); then compound 2.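

In this assay, moving from the 4-(trifluoromethyl)benzyl group to the 4-chlorobenzyl group gives a 1.1-fold higher number from compound 1 to compound 3 (0.05 log units; within the scatter) and so leaves the two compounds indistinguishable, even though four heavy atoms leave and only one enters at this place on the aromatic ring. Going by these compounds alone, this is the first comparison here that isolates a single change, whereas compound 1 and compound 2 differ in several places at once and could not show what this position alone contributes. Nothing measured here explains why chloro and trifluoromethyl read alike at this position.

Still open, going by these compounds, is whether the same holds for other groups at this place, such as a methoxy group, a nitrile or a carboxylic acid, or for a plain hydrogen there. Equally open, on these data alone, is what the chain and the sulfonyl-bearing ring each contribute on their own, for instance whether a longer chain on compound 3 would shift its number beyond the usual scatter of repeated measurements.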